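This account rests on a few compounds, and the source may have more. Where it says the series, first, only, none or still open, it means among the compounds named here.

Series notes. Compound 1 `Cc1oc(-c2ccc(Cl)cc2)nc1CN1CCC(C(=O)NCCCN2C[C@H](C)C[C@H](C)C2)CC1` carries a 4-chlorophenyl on the shared core. In an ADME assay on microsomes from liver (Rattus norvegicus) for metabolic stability, read by LC-MS, using NADPH, at 37 degrees C (a lower number here means that the compound disappears faster, a higher number that the compound lasts longer), compound 1 gives > 0.5 h, which is a limit of the assay rather than a number. Among the compounds with values here, compound 2 `Cc1ccccc1-c1nc(CN2CCC(C(=O)NCCCN3CCCC(CC(C)C)C3)CC2)c(C)o1` is the one member with a plain number: in this assay compound 2 gives 0.0383 h. Compound 3 `Cc1ccccc1-c1nc(CN2CCC(C(=O)N3CCN(C4CCN(C)CC4)CC3)CC2)c(C)o1` in this assay gives > 0.5 h, again a limit. Within the data shown here, the values therefore sit at the limit of > 0.5 h in this assay, at which 2 of the 3 values shown sit, with compound 2 as the outlier; no pair of these three differs in only one place, so no measured step exists.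

Compound 4 `COc1cccc(Cl)c1-c1nc(CN2CCC(C(=O)NCCCN3C[C@H](C)C[C@H](C)C3)CC2)c(C)o1` is not yet measured. Its difference from compound 1: 2-chloro-6-methoxyphenyl in place of 4-chlorophenyl on an aromatic carbon. Expectation for compound 4 in this assay: the step is expected to be none beyond the scatter, since compound 1 already sits at the limit of > 0.5 h in this assay, at which 2 of the 3 values shown sit, and the change enters a 2-chloro-6-methoxyphenyl of the same ring count. Compound 4 is expected to give 0.5 h, with a range of 0.15 h to 1.5 h. The estimated step of a number no higher from compound 1 to compound 4 (the limit leaves the size open) is expected to be flat, and a further limit read-out is as likely as a number.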

Compound 4, half-life: 0.055 h
The estimate for compound 4 lay 9.1-fold (0.96 log units) above the measured number, outside the stated range (below it).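

In this assay, the aryl group on the shared core proves sensitive to substitution: 2-chloro-6-methoxyphenyl in place of 4-chlorophenyl gives an at least 9.0-fold lower number from compound 1 to compound 4 (0.95 log units; beyond the scatter), with the rest of the structure unchanged. Retaining one six-membered aromatic ring of carbon only does not keep the number at the limit, and this is the first single change in the series that can be read. The size of the step remains open on one side, as its starting value is a limit: the limit of > 0.5 h in this assay, at which 2 of the 4 values shown sit.

The compounds shown leave open whether the chlorine or the methoxy group, or only their combination, accounts for the step. A phenyl carrying methoxy alone or chlorine alone, on the same side chain, would separate these readings.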